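Phenylsulfonyl in place of dichlorophenyl at the shared core

A few compounds are considered here, and "the series" means these few. Any claim that something is new, unique, unknown or untested is made for them only; others in the source may bear on it.

Two compounds of this series have numbers in a functional assay on Jurkat cells for inhibition of nuclear factor NF-kappa-B complex (Homo sapiens); on this read-out lower numbers stand for stronger inhibition and higher numbers for weaker inhibition. Compound 1 `CCOC(=O)c1cnc(-n2nc(C)cc2C)nc1NN1C(=O)C=C(C)C1=O` gives 10000 nM, and compound 2 `CCOC(=O)c1cnc(-c2cc(Cl)cc(Cl)c2)nc1NN1C(=O)C=C(C)C1=O` gives 300 nM. Among the measured compounds shown here, the single one-place step so far, a 33-fold lower number from compound 1 to compound 2 (1.52 log units; beyond the scatter), is large and beyond the scatter. For the measured compounds named here, compound 2 therefore holds the lower of the two numbers, with compound 1 as its only neighbour at a far higher value.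

Compound 3 `CCOC(=O)c1cnc(S(=O)(=O)c2ccccc2)nc1NN1C(=O)C=C(C)C1=O` is not yet measured. It differs from compound 2 in one place: phenylsulfonyl in place of 3,5-dichlorophenyl on an aromatic carbon. Going by the values given here, the one measured step concerns a different exchange, 3,5-dichlorophenyl for 3,5-dimethyl-1H-pyrazol-1-yl, and no measured step involves a phenylsulfonyl group. That step shows that the site is sensitive to what sits on it, so a shift beyond the scatter is plausible in either direction; lacking a precedent, the expectation is set within the span of the two measured numbers, nearer the weaker end. For compound 3 the estimated value is 2000 nM, in the range 300 nM to 10000 nM, which is an expected step of a 6.7-fold higher number from compound 2 to compound 3 (0.82 log units; beyond the scatter).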

Compound 3, half-maximal inhibitory concentration: 10000 nM
For compound 3 the middle estimate is 5.0-fold (0.70 log units) below the measured one; measured number inside the range.
By their numbers in this assay, from the lowest: compound 2; then compounds 1 and 3 (each within the scatter of the next).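

In this assay the phenylsulfonyl group gives up the whole advantage held by 3,5-dichlorophenyl on this aromatic carbon between two ring nitrogen atoms, with a 33-fold higher number from compound 2 to compound 3 (1.52 log units; beyond the scatter) as a large step beyond the scatter. Set against 3,5-dimethyl-1H-pyrazol-1-yl, the same group gives no change at the digits printed from compound 1 to compound 3 (within the scatter) so two structurally different groups cannot be told apart on this read-out, and among the three groups shown only 3,5-dichlorophenyl stands apart. A six-membered aromatic ring of carbon only is thus not sufficient at this place, since compound 3 carries one as well, and nothing measured here accounts for the difference.

The exchange from compound 2 to compound 3 removes the two chlorine atoms and inserts the sulfonyl link in a single step, so the compounds shown cannot say which of the two changes carries the loss. Unsubstituted phenyl joined directly to this carbon would separate those two changes, while a 3-chlorophenyl or a dimethylamino group would show how narrow the preference at this place is.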